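This account rests on a few compounds, and the source may have more. Where it says the series, first, only, none or still open, it means among the compounds named here.

Working notes on the series. Two compounds carry the shared core, compound 1 `Cc1cc(O)c(C2=NN(c3ccc(S(N)(=O)=O)cc3)C(/C=C/c3ccccc3)C2)cc1Cl` and compound 2 `COc1ccc(C2CC(c3cc(Cl)c(C)cc3O)=NN2c2ccc(S(N)(=O)=O)cc2)cc1OC`. In a functional assay on SK-MEL-5 cells (Homo sapiens) for antiproliferative activity, with a stated time of 48 h (on this read-out higher numbers stand for weaker inhibition of growth and lower numbers for stronger inhibition of growth), compound 1 gives 4230 nM, and in this assay compound 2 gives 4280 nM. The step of a 1.0-fold higher number from compound 1 to compound 2 (0.01 log units; within the scatter) shows that the exchange at the saturated ring carbon leaves the read-out essentially unchanged; compound 2 and compound 1 lie within the scatter of each other, so neither stands apart on the numbers seen so far.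

Compound 3 `COc1ccc(C2CC(c3cc(Cl)c(C)cc3O)=NN2c2ccc(S(N)(=O)=O)cc2)c(OC)c1OC` has not been measured. It differs from compound 2 by methoxy in place of hydrogen on an aromatic carbon. For the measured compounds named here, no measured step adds a methoxy group to the aromatic ring on the saturated ring carbon; the only step in hand, from compound 1 to compound 2, replaces that whole ring system and is within the scatter. A methoxy added to a ring whose exchange already left the number flat is expected to give no step beyond the scatter, so a 1.0-fold higher number from compound 2 to compound 3 (0.00 log units; within the scatter) is the expected change in this assay. Compound 3 is therefore estimated at 4300 nM in this assay, with a range from 2000 nM to 9500 nM.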

Compound 3, concentration for 50% growth inhibition: 2020 nM
For compound 3 the middle estimate is 2.1-fold (0.33 log units) above the measured one, and the stated range covers the measured number.
By their numbers in this assay, from the lowest: compound 3; then compounds 1 and 2 (each within the scatter of the next).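

For the compounds shown here, the methoxy on the aromatic carbon, ortho to a large group, ortho to a methoxy group and meta to a methoxy group, is the first change to pass the scatter, with a 2.1-fold lower number from compound 2 to compound 3 (0.33 log units; beyond the scatter) in this assay as a modest step. The aryl group on the saturated ring carbon therefore can move the read-out, even though 3,4-dimethoxyphenyl in place of 2-phenylethenyl gave a 1.0-fold higher number from compound 1 to compound 2 (0.01 log units; within the scatter) and did not; 2,3,4-trimethoxyphenyl in that same exchange gives a 2.1-fold lower number from compound 1 to compound 3 (0.32 log units; beyond the scatter) and so stands apart from the flat first step. Going by these compounds alone, no measurement on these compounds speaks to the origin of this step.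

The compounds shown leave open whether the step belongs to methoxy itself, or whether ethoxy, a longer alkoxy chain or an amine on the same aromatic carbon would give a step of like size. Within the data shown here, they also leave open whether a methoxy at this place needs the other two methoxy groups on the ring, since it is seen only on the 3,4-dimethoxyphenyl ring of compound 2.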